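The source may hold more compounds than are shown below. What is called first, only, known or untested is meant among the compounds shown, and "the series" means these compounds.

- compound 1 `CC(C)CCn1c(CN2C(=O)C(CC(=O)O)c3ccccc32)nc2ccccc21`: 16500 nM
- compound 2 `CN(C)CCn1c(CN2C(=O)CCc3ccccc32)nc2ccccc21`: 153000 nM

In an ADME assay on HEp-2 cells (Homo sapiens) for cytotoxicity (on this read-out lower numbers stand for higher toxicity in this test and higher numbers for lower toxicity in this test), compound 1 gives 16500 nM, the lower of the two numbers, while compound 2 gives 153000 nM, and the gap between the two lies beyond the usual scatter. Compound 3 `CC(C)CCn1c(CN2C(=O)C(CC(=O)N(C)C)c3ccccc32)nc2ccccc21` keeps the core of compound 1 and changes one place, with dimethylamino in place of hydroxy on a carbonyl carbon. Among the compounds with values here, no measured pair shows this change, so no direction can be read from the data, and no step beyond the scatter is expected. The expected result is a 1.0-fold lower number from compound 1 to compound 3 (0.01 log units; within the scatter). For compound 3 the estimate is 16000 nM, with an expected range from 5000 nM to 60000 nM.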

Compound 3, half-maximal cytotoxic concentration: 4670 nM
The estimate for compound 3 lay 3.4-fold (0.53 log units) above the measured number; the whole stated range lies above it.
By their numbers in this assay, from the lowest: compound 3; then compound 1; then compound 2.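

In this assay the change from hydroxy to dimethylamino on this carbonyl carbon gives a 3.5-fold lower number from compound 1 to compound 3 (0.55 log units; beyond the scatter) and so moves the read-out toward higher toxicity in this test. Within the data shown here, this is the first single-place step, showing that this carbonyl carbon's substituent can alter the read-out, something compound 1 and compound 2, which differ in more than one place, could not show. Nothing available explains this shift.

Still open, going by these compounds, is where a smaller amino group or a methoxy group on this carbonyl carbon would fall relative to compound 1 and compound 3. Also open, on these data alone, is whether the same change would give a similar step with a different chain on the shared core.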